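The source may hold more compounds than are shown below. What is called first, only, known or untested is meant among the compounds shown, and "the series" means these compounds.

Measured so far:
Compound 1 `CCN(CC)CCCCCCOc1ccc2oc(-c3ccccc3)cc(=O)c2c1`: in an assay on isolated protein (Cavia porcellus) with Sigma non-opioid intracellular receptor 1 (Homo sapiens) as the target, read by radioligand binding (on this read-out lower numbers stand for stronger inhibition and higher numbers for weaker inhibition), compound 1 gives 100 nM.
Compound 2 `CCOC(=O)C1CCN(CCCCCCOc2ccc3oc(-c4ccccc4)cc(=O)c3c2)CC1`: in this assay compound 2 gives 102 nM.

Compound 2 holds the higher of the two numbers, yet its neighbour compound 1 sits within the scatter of it, so the two cannot be told apart. Among the compounds with values here, the single measured step, a 1.0-fold higher number from compound 1 to compound 2 (0.01 log units; within the scatter), shows that exchanging one tertiary amine for another at the chain end left the read-out unchanged.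

Compound 3 `NCCCCCCOc1ccc2oc(-c3ccccc3)cc(=O)c2c1` carries the change (amino in place of 4-(ethoxycarbonyl)piperidin-1-yl on a saturated chain carbon, six bonds along the chain from an oxygen on an aromatic ring). Within the data shown here, the step from compound 1 to compound 2 bears on it only loosely: both of those compounds keep a fully substituted nitrogen, whereas compound 3 strips the chain end down to a primary amine, a change of a different kind that no measured pair covers. Without a direct precedent, the outcome is uncertain, and a modest weakening of this assay is expected, a 4.9-fold higher number from compound 2 to compound 3 (0.69 log units; beyond the scatter). Compound 3 is therefore estimated at 500 nM, with a range from 100 nM to 3000 nM.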

Compound 3, half-maximal inhibitory concentration: 3700 nM
Compound 3: the middle estimate sits 7.4-fold (0.87 log units) below what was measured, and the stated range ends below it.
By their numbers in this assay, from the lowest: compounds 1 and 2 (each within the scatter of the next); then compound 3.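

In this assay, amino in place of 4-(ethoxycarbonyl)piperidin-1-yl gives a 36-fold higher number from compound 2 to compound 3 (1.56 log units; beyond the scatter) and amino in place of diethylamino gives a 37-fold higher number from compound 1 to compound 3 (1.57 log units; beyond the scatter) as a large step in the same direction. The earlier pair had suggested that this place, on a saturated chain carbon six bonds along the chain from an oxygen on an aromatic ring, tolerates change, but these steps show that this holds only for the two substituted amines compared there and that the read-out does respond to the group at the chain end. No measurement shown here explains why the number rises so far with amino.

The compounds shown leave open whether an intermediate amine, such as methylamino or ethylamino, stays with compound 1 and compound 2 or falls with compound 3. They also leave open whether unsubstituted piperidine behaves like its ester-bearing counterpart, and how a shorter or longer chain would alter these steps.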